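Swapping the aryl group on a ring nitrogen

The compounds below may be only part of what the source reports. "The series", "measured", "known", "first", "only" and "open" are said of these compounds alone.

In a functional assay on PC-12 cells (Rattus norvegicus) for cytotoxicity, read by MTT assay, with stated times of 2 h and 24 h, tested at 10 uM (on this read-out higher numbers stand for a stronger effect at the one concentration tested and lower numbers for a weaker effect), compound 1 `Oc1cc(C(F)(F)F)ccc1-c1nc(-c2ccccc2O)n(-c2ccc(F)cc2)n1` gives 99.8%, and compound 2 `COc1ccc(-n2nc(-c3ccc(C(F)(F)F)cc3O)nc2-c2ccccc2O)cc1` gives 98.9%; the step of a number 0.9 percentage points lower from compound 1 to compound 2 (within the scatter) means the two sit within the scatter of each other. Compound 3 `Oc1cc(C(F)(F)F)ccc1-c1nc(-c2ccccc2O)n(-c2ccccc2F)n1` differs from compound 2 by 2-fluorophenyl in place of 4-methoxyphenyl on an aromatic nitrogen. Going by the values given here, the one measured step exchanged a different group, so no step bears directly on this change; since both measured compounds give numbers near the top of the scale, the step of a number 1.9 percentage points lower from compound 2 to compound 3 (within the scatter) is expected to stay within the scatter. Compound 3 is therefore estimated at 97%, between 85% and 100%.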

Compound 3, a percentage reported as activity, at one concentration (the size of the read-out at that concentration, not a potency): 100%
For compound 3 the middle estimate is 3 percentage points below the measured one; the range from low to high includes it.
By their numbers in this assay, from the lowest: compounds 2, 1 and 3 (each within the scatter of the next).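

With the 2-fluorophenyl group on this ring nitrogen, the read-out in this assay stays put: there is a number 1.1 percentage points higher from compound 2 to compound 3 (within the scatter) and a number 0.2 percentage points higher from compound 1 to compound 3 (within the scatter). The second step shows that placing the fluorine on a different ring carbon of the phenyl group makes no difference beyond the scatter here, just as replacing the 4-methoxyphenyl group does not. No available evidence accounts for these numbers. Going by these compounds, all three compounds sit near the top of the scale, so it remains open whether a carboxylic acid or an amine on this phenyl ring would give a lower number.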